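This account rests on a few compounds, and the source may have more. Where it says the series, first, only, none or still open, it means among the compounds named here.

Measured in a functional assay on U-251 cells (Homo sapiens); on this read-out lower numbers stand for stronger inhibition of growth and higher numbers for weaker inhibition of growth:
- compound 1 `O=S(=O)(/C=C/c1ccc(C(F)(F)F)cc1F)Cc1ccc(Nc2ncnc3ccccc23)cc1`: 100000 nM
- compound 2 `O=S(=O)(/C=C/c1ccc(Br)cc1)Cc1ccc(Nc2ncnc3ccc(Br)cc23)cc1`: 11000 nM
- compound 3 `O=S(=O)(/C=C/c1ccc(Cl)cc1Cl)Cc1ccc(Nc2ncnc3ccc(Br)cc23)cc1`: 4000 nM
- compound 4 `O=S(=O)(/C=C/c1ccc(C(F)(F)F)cc1F)Cc1ccc(Nc2ncnc3ccc(Br)cc23)cc1`: not yet measured

Of the three measured compounds, compound 3 has the lowest number (4000 nM), which makes it the strongest growth inhibitor so far. Compound 4 keeps the core of compound 3 and changes one group: 2-fluoro-4-(trifluoromethyl)phenyl in place of 2,4-dichlorophenyl on a double-bonded chain carbon bound to a double-bonded chain carbon.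

Among the measured compounds shown here, only one measured step involves a change at this place (a 2.8-fold lower number from compound 2 to compound 3 (0.44 log units; beyond the scatter)), and it is modest. Compound 1 (100000 nM) carries the same 2-fluoro-4-(trifluoromethyl)phenyl as compound 4, and its number is far higher than that of compound 3. Its core differs from that of compound 3, however, so the gap cannot be credited to the group alone. The data hold no direct comparison of the two groups on one core.

A modest rise in the number is therefore expected in this assay, estimated as a 1.8-fold higher number from compound 3 to compound 4 (0.24 log units; within the scatter). For compound 4 the estimate is 7000 nM, with an expected range from 2500 nM to 25000 nM.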

Compound 4, concentration for 50% growth inhibition: 30000 nM
The estimate for compound 4 lay 4.3-fold (0.63 log units) below the measured number; the measured number lies above the stated range.
By their numbers in this assay, from the lowest: compound 3; then compound 2; then compound 4; then compound 1.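

In this assay, among the compounds shown here, the earlier compounds offered no direct comparison of these two groups on one core, and replacing 2,4-dichlorophenyl with 2-fluoro-4-(trifluoromethyl)phenyl now supplies it, with a 7.5-fold higher number from compound 3 to compound 4 (0.88 log units; beyond the scatter) showing clearly weaker growth inhibition. The same group also compares poorly with 4-bromophenyl, as a 2.7-fold higher number from compound 2 to compound 4 (0.44 log units; beyond the scatter) makes plain, so on this core the three groups run from 2,4-dichlorophenyl through 4-bromophenyl to 2-fluoro-4-(trifluoromethyl)phenyl, each step beyond the usual scatter. With that group held fixed, bromo in place of hydrogen on an aromatic carbon gives a 3.3-fold lower number from compound 1 to compound 4 (0.52 log units; beyond the scatter).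

No supporting measurement bears on why the groups fall in this order. Still open, as far as these compounds go, is whether a phenyl ring carrying an amine or a carboxylic acid at this place would bring the number lower, and whether the same order of groups would hold on the core without bromo.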